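A few compounds are considered here, and "the series" means these few. Any claim that something is new, unique, unknown or untested is made for them only; others in the source may bear on it.

Measured compounds:
Compound 1, `Cc1ccccc1NS(=O)(=O)c1ccc(N2CCNC2=O)cc1`, gives 150 nM in a functional assay on M21 cells (Homo sapiens) for antiproliferative activity, read by sulforhodamine B assay, with a stated time of 48 h; on this read-out lower numbers stand for stronger inhibition and higher numbers for weaker inhibition.
Compound 2, `O=C1NCCN1c1ccc(S(=O)(=O)Nc2ccc(C3CCCCC3)cc2)cc1`, gives only a limit, > 1000 nM, in this assay.
Compound 3, `CCCCCCOc1ccc(NS(=O)(=O)c2ccc(N3CCNC3=O)cc2)cc1`, likewise gives only a limit, > 1000 nM.

On the numbers shown, compound 1 holds the only number; the other two values are limits. For the measured compounds named here, the one measured step, a step that the two limits leave unreadable from compound 2 to compound 3, is unreadable, so nothing measured bears directly on the change from compound 1 to compound 4, `Cc1cc(C)cc(NS(=O)(=O)c2ccc(N3CCNC3=O)cc2)c1`: 3,5-dimethylphenyl in place of 2-methylphenyl on a sulfonamide nitrogen. Because the limit of > 1000 nM in this assay, at which 2 of the 3 values shown sit, sits on compounds bearing cyclohexyl or hexyloxy rather than a second methyl, it sets no direction for compound 4. Compound 4 is therefore expected to stay near compound 1, with an estimated step of a 1.7-fold higher number from compound 1 to compound 4 (0.22 log units; within the scatter) within the usual scatter. The estimate for compound 4 is 250 nM, between 80 nM and 1000 nM.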

Compound 4, half-maximal inhibitory concentration: 63 nM
Estimate against measurement, compound 4: 4.0-fold (0.60 log units) above; measured number below the stated range.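

For the compounds shown here, the swap of 2-methylphenyl for 3,5-dimethylphenyl on the sulfonamide nitrogen gives the first readable step at this position in this assay: a 2.4-fold lower number from compound 1 to compound 4 (0.38 log units; beyond the scatter). Going by these compounds alone, the earlier steps could not be read, as the compounds bearing cyclohexyl and hexyloxy gave only limits, so this is the first sign that a small change to this aromatic ring can lower the number. Nothing shown accounts for the gain.

The compounds shown leave open how a methoxy group or a chlorine atom on this ring would read, and whether an amine would be tolerated there.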